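Demethylation of the allyl(methyl)amino nitrogen in compound 1

The compounds below may be only part of what the source reports. "The series", "measured", "known", "first", "only" and "open" are said of these compounds alone.

Compound 1 `C=CCN(C)c1nc(N)nc2c1ncn2[C@H]1C[C@H](N=[N+]=[N-])[C@@H](CO)O1` anchors the series. In an ADME assay on PBMC cells (Homo sapiens) for cytotoxicity, with a stated time of 5 days (a lower number here means a stronger inhibitor, a higher number a weaker inhibitor), compound 1 gives > 100000 nM, which is a limit of the assay rather than a number. Compound 2 `COc1nc(Cl)nc2c1ncn2[C@H]1C[C@H](N=[N+]=[N-])[C@@H](CO)O1` is also known only by a limit: in this assay compound 2 gives > 100000 nM. Compound 3 `COc1nc(OC)c2ncn([C@H]3C[C@H](N=[N+]=[N-])[C@@H](CO)O3)c2n1` follows the same pattern, and in this assay compound 3 gives > 100000 nM, again a limit. Among the compounds with values here, the single one-place step among the measured compounds is the methoxy in place of chloro on an aromatic carbon, a step that the two limits leave unreadable from compound 2 to compound 3, so its size stays hidden. What the three measured compounds show together is the limit of > 100000 nM in this assay, at which 3 of the 3 values shown sit.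

Compound 4 `C=CCNc1nc(N)nc2c1ncn2[C@H]1C[C@H](N=[N+]=[N-])[C@@H](CO)O1` departs from compound 1 by hydrogen in place of methyl on a nitrogen on an aromatic ring. Within the data shown here, no measured step touches the nitrogen on the aromatic ring, and the one step that exists cannot be sized, so nothing argues for a shift in either direction. On that basis the step from compound 1 to compound 4 is expected to be a step that the limit leaves unreadable from compound 1 to compound 4, nothing beyond the scatter, and most likely the read-out for compound 4 will again be a limit. The estimate for compound 4 is 150000 nM, with a range from 50000 nM to 500000 nM.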

Compound 4, half-maximal inhibitory concentration: > 100000 nM
Compound 4: no number, only a limit; the forecaster's own chance of this, stated with the estimate: 80%; the middle value lies beyond the limit too.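

In this assay compound 4 gives > 100000 nM, a limit of the assay and not a number. With compound 1 also known only by a limit, the change from allyl(methyl)amino to allylamino between compound 1 and compound 4 cannot be sized: the limit of > 100000 nM in this assay, at which 4 of the 4 values shown sit.

The compounds shown leave open what half-maximal inhibitory concentration any of them has in this assay, and whether any one-place change alters it.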